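Swapping Carboxy for Methylpiperazine: What Cell Inhibition May Show

The source may hold more compounds than are shown below. What is called first, only, known or untested is meant among the compounds shown, and "the series" means these compounds.

Of the compounds shown here, three with a shared core have been tested in an ADME assay on HepG2 cells (Homo sapiens) for inhibition, read by fluorescence and resazurin assay, with a stated time of 72 h; a higher number here means a weaker inhibitor, a lower number a stronger inhibitor. Compound 1 `NS(=O)(=O)c1cccc(Nc2nccc(Nc3ccc4nc[nH]c4c3)n2)c1` gives in this assay only a limit, > 25000 nM. Compound 2 `O=C(O)c1ccc(Nc2nccc(Nc3ccc4nc[nH]c4c3)n2)cc1` gives in this assay likewise only a limit, > 25000 nM. Compound 3 `NC(=O)c1ccc(Nc2nccc(Nc3ccc4cn[nH]c4c3)n2)cc1`, whose core also varies slightly, gives in this assay a number, 16000 nM. Compound 2 therefore stands at the limit of > 25000 nM in this assay, at which 2 of the 3 values shown sit, and no number separates it from compound 1; only compound 3 delivers a value that the assay could resolve.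

Compound 4 `CN1CCN(c2ccc(Nc3nccc(Nc4ccc5nc[nH]c5c4)n3)cc2)CC1` is the compound still to be measured. It differs from compound 2 in one place: 4-methylpiperazin-1-yl in place of carboxy on an aromatic carbon. Within the data shown here, no step between two measured compounds shows what this change does here, so the expectation rests on the general picture. In this assay the expected step is an at least 3.1-fold lower number from compound 2 to compound 4 (0.49 log units; beyond the scatter), toward stronger inhibition and beyond the usual scatter. This expectation leans on compound 3, which gives 16000 nM rather than a limit. For compound 4 the estimate in this assay is 8000 nM, with a range from 2000 nM to 25000 nM, and a result reported only as a limit remains possible.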

Compound 4, half-maximal inhibitory concentration: > 25000 nM
Compound 4 gave a limit, no number (the forecaster's own chance of this, stated with the estimate: 30%); at least 3.1-fold (0.49 log units) between middle value and limit.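

Compound 2 and compound 4 each give only a limit, not a number, so the swap from carboxy to 4-methylpiperazin-1-yl yields no readable step: the limit of > 25000 nM in this assay, at which 3 of the 4 values shown sit. Going by these compounds, whether this swap strengthens or weakens inhibition in this assay stays open, as does how far the true values of compound 2 and compound 4 lie beyond their limits.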